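Chalcone-Coumarin Series: Dimethoxyphenyl Variant, Expectation Before Measurement

This account rests on a few compounds, and the source may have more. Where it says the series, first, only, none or still open, it means among the compounds named here.

Working notes on the shared core. Compound 1 `COc1cccc(COc2ccc3cc(C(=O)/C=C/c4ccc(Cl)cc4Cl)c(=O)oc3c2)c1` and compound 2 `COc1cccc(COc2ccc3cc(C(=O)/C=C/c4ccccc4)c(=O)oc3c2)c1` carry the same core and differ only in the aromatic group on the double-bonded chain. In a functional assay on MOLT-4 cells (Homo sapiens) for cytotoxicity, read by MTT assay, with a stated time of 72 h (on this read-out higher numbers stand for weaker inhibition and lower numbers for stronger inhibition), compound 1 gives "not determined" (no result reported), so it contributes no number to the comparison. In this assay compound 2 gives > 100000 nM, which is a limit of the assay and not a measured number. Where compound 2 stands is therefore fixed only by the limit of > 100000 nM in this assay, at which 1 of the 2 values shown sits; no step between measured compounds exists in this assay, and nothing here shows how a change on the double-bonded chain moves the read-out.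

Compound 3 `COc1cccc(COc2ccc3cc(C(=O)/C=C/c4cc(OC)ccc4OC)c(=O)oc3c2)c1` is the next variant: 2,5-dimethoxyphenyl in place of phenyl on a double-bonded chain carbon bound to a double-bonded chain carbon. For the measured compounds named here, with no measured step to lean on, the expectation for compound 3 rests on compound 2 sitting at > 100000 nM as a limit, and the step from compound 2 to compound 3 is expected to be none beyond the usual scatter, as an at least 1.1-fold lower number from compound 2 to compound 3 (0.04 log units; that floor lies within the scatter). Compound 3 is accordingly estimated at 90000 nM in this assay, with a range from 20000 nM to 400000 nM, and a further limit-only result is considered the more likely outcome.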

Compound 3, half-maximal inhibitory concentration: 13800 nM
For compound 3 the middle estimate is 6.5-fold (0.81 log units) above the measured one; the measured number lies below the stated range.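

In this assay, for the compounds shown here, 2,5-dimethoxyphenyl in place of phenyl on a double-bonded chain carbon bound to a double-bonded chain carbon gives the first step that can be read, an at least 7.2-fold lower number from compound 2 to compound 3 (0.86 log units; beyond the scatter), which shows that the read-out responds to a change at this position. Going by these compounds alone, compound 3 also supplies the first single number on the shared core, 13800 nM, so the series now has a measured reference point for further changes on the double-bonded chain. The step is a floor and not a full size, because compound 2 stands at a limit of the assay: the limit of > 100000 nM in this assay, at which 1 of the 3 values shown sits.

Steps involving compound 1 cannot be read, so the compounds shown offer only one change at this position and no trend across aromatic groups. They leave open whether both methoxy groups are needed for the step and whether a dimethylamino group or a carboxylic acid on the same aromatic ring would lower the number further, leave it unchanged or raise it.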